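One group swapped, and a cytotoxicity estimate

The source may report more compounds than this note shows. Statements on the series, on what has been measured and on what is new or still open speak of the compounds shown alone.

Compound 1 `CN(C)c1ccc(-c2ccc(Cl)cc2)c(COc2ccc(-c3nc4cc(C(=O)O)ccc4n3C3CCCCC3)cc2)c1` gives 30000 nM
Compound 2 `O=C(O)c1ccc2c(c1)nc(-c1ccc(OCc3cc(C(=O)NCCO)ccc3-c3ccc(Cl)cc3)cc1F)n2C1CCCCC1` gives 26000 nM

Both values come from a functional assay on Huh-5-2 cells (Homo sapiens), read by MTT assay (on this read-out lower numbers stand for higher toxicity in this test and higher numbers for lower toxicity in this test), and they lie within the usual scatter of each other, so compound 2 at 26000 nM stands level with compound 1 on these numbers.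

Compound 3 `CC(=O)Nc1ccc(-c2ccc(Cl)cc2)c(COc2ccc(-c3nc4cc(C(=O)O)ccc4n3C3CCCCC3)c(F)c2)c1` keeps the rest of compound 2 but carries acetamido in place of (2-hydroxyethyl)carbamoyl on an aromatic carbon in a spot that is para to a 4-chlorophenyl group.

Going by the values given here, no two measured compounds differ in one place only, so no measured step shows what this swap does. Compound 1 at 30000 nM and compound 2 at 26000 nM differ in more than one place and still fall within the scatter. In this assay the expected result is a 1.0-fold lower number from compound 2 to compound 3 (0.02 log units; within the scatter) and so no step beyond the scatter. For compound 3 the estimated value is 25000 nM with an expected span from 11000 nM to 55000 nM as its range.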

Compound 3, half-maximal cytotoxic concentration: 24000 nM
The estimate for compound 3 lay 1.0-fold (0.02 log units) above the measured number, within the range that was stated.
By their numbers in this assay, from the lowest: compounds 3, 2 and 1 (each within the scatter of the next).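

Going by these compounds alone, compound 2 and compound 3 form the first pair here that differs in one place only: the group on an aromatic carbon para to a 4-chlorophenyl group. In this assay the swap to acetamido from (2-hydroxyethyl)carbamoyl gives a 1.1-fold lower number from compound 2 to compound 3 (0.03 log units; within the scatter) and so shows that, at this position, going from 6 heavy atoms to 4 and from 2 hydrogen-bond donors to 1 produces no step beyond the scatter in this test of toxicity. No measurement at hand bears on the reason for this result, so it stands as a plain observation on one pair.

One swap cannot show how far this position tolerates change. A nitrile, a sulfonamide or a longer chain ending in an amine could still behave differently here in this assay, and these two compounds cannot settle that.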